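Stereoisomers at the assay limit: compound 3 to compound 4

The compounds below may be only part of what the source reports. "The series", "measured", "known", "first", "only" and "open" are said of these compounds alone.

- compound 1 `O=C(O)[C@H](CO)NC(=O)[C@H]1C[C@H](O)CN1`: > 12 h (a limit)
- compound 2 `O=C(O)[C@@H](CO)NC(=O)[C@H]1C[C@@H](O)CN1`: > 12 h (a limit)
- compound 3 `O=C(O)[C@H](CO)NC(=O)[C@@H]1C[C@H](O)CN1`: > 12 h (a limit)

The read-out throughout is an ADME assay on Colon (Mus musculus, strain C57BL/6) for metabolic stability, read by HPLC, with a stated time of 12 h; on this read-out higher numbers stand for a longer-lived compound and lower numbers for a shorter-lived compound. All three compounds share one ceiling: the limit of > 12 h in this assay, at which 3 of the 3 values shown sit. Compound 3 therefore has no number of its own and no rank within the series.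

Compound 4 `O=C(N[C@H](CO)C(=O)O)[C@@H]1C[C@@H](O)CN1` has the same atoms and bonds as compound 3, and the change is the two compounds have the same atoms and bonds and differ only in configuration as drawn: 2 of 3 stereo elements differ; a stereocentre at a saturated chain carbon is drawn S in compound 3 and R in compound 4; a stereocentre at a saturated ring carbon is drawn S in compound 3 and R in compound 4.

Within the data shown here, the closest precedent is a step that the two limits leave unreadable from compound 1 to compound 2, which inverts the same two kinds of stereocentre, one at a saturated chain carbon and one at a saturated ring carbon. Also relevant are a step that the two limits leave unreadable from compound 1 to compound 3 and a step that the two limits leave unreadable from compound 2 to compound 3. None of the three has a readable size, so no direction can be drawn from them.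

In this assay, no step beyond the scatter is expected, and the expected step that the limit leaves unreadable from compound 3 to compound 4 has no readable direction. Compound 4 is estimated at 15 h, with an expected range of 12 h to 24 h, and will most likely be reported only as a limit.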

Compound 4, half-life: > 12 h
Compound 4: only a limit was reported; the forecaster's own chance of this, stated with the estimate: 90%; the middle value is on the limit's open side.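

In this assay compound 4 gives > 12 h, which is a limit, so no step between compound 4 and compound 1, compound 2 or compound 3 can be read: the limit of > 12 h in this assay, at which 4 of the 4 values shown sit.

The compounds shown leave open the actual half-life of each of the four stereoisomers and whether configuration changes it at all.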